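This account rests on a few compounds, and the source may have more. Where it says the series, first, only, none or still open, it means among the compounds named here.

Values in a functional assay on HeLa cells (Homo sapiens) for antiproliferative activity, read by MTT assay, with a stated time of 48 h; a higher number here means a weaker inhibitor, a lower number a stronger inhibitor:
- compound 1 `Brc1ccc2[nH]c(-c3cn(-c4ccccc4)nc3-c3ccccc3)nc2c1`: 1760 nM
- compound 2 `Clc1ccc(-c2nn(-c3ccccc3)cc2-c2nc3ccccc3[nH]2)cc1`: 1650 nM
- compound 3 `Clc1ccc(-c2nn(-c3ccccc3)cc2-c2nc3cc(Cl)ccc3[nH]2)cc1`: 1630 nM

Compound 3, at 1630 nM, stands level with the other two compounds, as its gaps to both lie within the scatter. The next compound to consider is compound 4 `Clc1ccc(-c2nn(-c3ccccc3)cc2-c2nc3cc(Br)ccc3[nH]2)cc1`, which differs from compound 3 by bromo in place of chloro on an aromatic carbon, with bromo in place of chloro on an aromatic carbon.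

For the measured compounds named here, only one measured step bears directly on this position: a 1.0-fold lower number from compound 2 to compound 3 (0.01 log units; within the scatter). Chloro in place of hydrogen therefore left this assay unmoved. Going by the values given here, compound 1, the only measured compound carrying bromo, gives 1760 nM, also level with compound 3, although no measured step isolates the bromo group. The data thus offer no reason to expect a shift in either direction.

The expected outcome is a 1.0-fold lower number from compound 3 to compound 4 (0.01 log units; within the scatter), which would be no step beyond the scatter. For compound 4 the estimated value is 1600 nM, with an expected range of 1000 nM to 2500 nM.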

Compound 4, half-maximal inhibitory concentration: 2160 nM
Estimate against measurement, compound 4: 1.4-fold (0.13 log units) below; low and high end bracket the measured number.
By their numbers in this assay, from the lowest: compounds 3, 2, 1 and 4 (each within the scatter of the next).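

Bromo at this aromatic carbon can now be set against both chloro and hydrogen in this assay and neither step leaves the scatter, with a 1.3-fold higher number from compound 3 to compound 4 (0.12 log units; within the scatter) and a 1.3-fold higher number from compound 2 to compound 4 (0.12 log units; within the scatter) as the two readings. The earlier compounds shown here held no step that isolated bromo here; on the shared core, hydrogen, chloro and bromo at this place are now not told apart. Chloro in place of hydrogen also stays within the scatter on a second core, with a 1.2-fold higher number from compound 1 to compound 4 (0.09 log units; within the scatter) as the new reading, and the two cases agree: the same change on two cores in this assay, a 1.0-fold lower number (0.01 log units; within the scatter) from compound 2 to compound 3 and a 1.2-fold higher number (0.09 log units; within the scatter) from compound 1 to compound 4, 1.2-fold (0.09 log units) apart, within the scatter of two such steps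

Open, going by these compounds, is whether this carbon responds to anything other than a halogen, such as an amine, a carboxylic acid or a methoxy group. All four compounds sit level, so nothing here shows which part of the structure governs the activity.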